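The compounds below may be only part of what the source reports. "The series", "measured", "known", "first", "only" and "open" are said of these compounds alone.

Compound 1 `O=C1CC(c2nc(-c3cccc(Cl)c3)no2)CN1c1ccc(Cl)cc1` carries 4-chlorophenyl on an amide-type nitrogen in a ring. In an in vitro functional assay on HEK293-A cells for negative allosteric modulation of metabotropic glutamate receptor 5 (Homo sapiens), read by FLIPR and calcium flux (on this read-out higher numbers stand for weaker inhibition and lower numbers for stronger inhibition), compound 1 gives > 10000 nM, which is a limit of the assay and not a number, as recorded in the limit of > 10000 nM in this assay, at which 1 of the 3 values shown sits; compound 1 therefore stands only as a limit against the two numbered values in the set. Compound 2 `O=C1CC(c2nc(-c3cccc(Cl)c3)no2)CN1c1ccccc1Cl` has 2-chlorophenyl in place of 4-chlorophenyl on an amide-type nitrogen in a ring, and in this assay compound 2 gives 680 nM. Compound 3 `Cc1ccccc1N1CC(c2nc(-c3cccc(Cl)c3)no2)CC1=O` has 2-methylphenyl at that place, and in this assay compound 3 gives 370 nM. The measured steps are an at least 14-fold lower number from compound 1 to compound 2 (1.16 log units; beyond the scatter) and an at least 27-fold lower number from compound 1 to compound 3 (1.43 log units; beyond the scatter), while a 1.8-fold lower number from compound 2 to compound 3 (0.26 log units; within the scatter) stays within the scatter.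

Compound 4 `O=C1CC(c2nc(-c3cccc(Cl)c3)no2)CN1c1cccc(Cl)c1` is not yet measured. Its change from compound 1 is 3-chlorophenyl in place of 4-chlorophenyl on an amide-type nitrogen in a ring. The two steps that bear on it are an at least 14-fold lower number from compound 1 to compound 2 (1.16 log units; beyond the scatter) and an at least 27-fold lower number from compound 1 to compound 3 (1.43 log units; beyond the scatter): both replace 4-chlorophenyl with another substituted phenyl and both lower the number beyond the scatter. For the measured compounds named here, no measured compound carries 3-chlorophenyl, so the size of its step is uncertain, but a lowering beyond the scatter in this assay is expected. Compound 4 is estimated at 2500 nM, within 600 nM to 10000 nM, which corresponds to an expected step of an at least 4.0-fold lower number from compound 1 to compound 4 (0.60 log units; beyond the scatter).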

Compound 4, half-maximal inhibitory concentration: 1100 nM
For compound 4 the middle estimate is 2.3-fold (0.36 log units) above the measured one, within the range that was stated.
By their numbers in this assay, from the lowest: compounds 3, 2 and 4 (each within the scatter of the next, the first and the last beyond it). At a limit, above all of these: compound 1.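

In this assay, moving the chloro group alone, with the same atoms joined differently, gives an at least 9.0-fold lower number from compound 1 to compound 4 (0.95 log units; beyond the scatter), so 3-chlorophenyl on an amide-type nitrogen in a ring keeps a measurable value where 4-chlorophenyl does not, and this step is only a bound because compound 1 stands at a limit of the assay: the limit of > 10000 nM in this assay, at which 1 of the 4 values shown sits.

The two chlorophenyl isomers with numbered values are not separated, with a 1.6-fold higher number from compound 2 to compound 4 (0.21 log units; within the scatter), so this series gives no order between 3-chlorophenyl and 2-chlorophenyl at this place. Against 2-methylphenyl, the change shows a 3.0-fold higher number from compound 3 to compound 4 (0.47 log units; beyond the scatter), the first step among numbered values at this position that lies beyond the scatter, although compound 2 remains within the scatter of both compound 3 and compound 4.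

Open, going by these compounds, is how 3-methylphenyl on the amide-type nitrogen would read against compound 3 and compound 4, which would part the effect of where the group sits from that of chloro versus methyl. Also open, on these data alone, is how unsubstituted phenyl or 3-methoxyphenyl would read at this place.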